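Swapping the Ring Amide for an Open-Chain Amine Amide

This account rests on a few compounds, and the source may have more. Where it says the series, first, only, none or still open, it means among the compounds named here.

Of the compounds shown here, three sharing one core have been measured: compound 1 `CN(CCCn1ccnc1)C(=O)[C@@H]1CCCN1c1nccc(Nc2ccccc2)n1`, compound 2 `COC(=O)C(CO)NC(=O)[C@@H]1CCCN1c1nccc(Oc2cccc(C)c2)n1` and compound 3 `COC[C@@H]1CCCN1C(=O)[C@@H]1CCCN1c1nccc(Nc2ccccc2)n1`. In an assay on isolated protein for inhibition of tyrosine-protein kinase ZAP-70 (Homo sapiens), read by HTRF, tested at 10 uM (on this read-out lower numbers stand for less inhibition and higher numbers for more inhibition at the one concentration tested (going by the name of the read-out)), compound 1 gives 3%, compound 2 gives 0% and compound 3 gives 6%, the highest of the three numbers, though its gaps to compound 1 and compound 2 both lie within the scatter. Compound 4 `CN(C)CC(C)(C)CNC(=O)[C@@H]1CCCN1c1nccc(Nc2ccccc2)n1` differs from compound 3 at the same carbonyl carbon: (2-((dimethylamino)methyl)-2-methylpropyl)amino in place of 2-(methoxymethyl)pyrrolidin-1-yl on a carbonyl carbon. Among the measured compounds shown here, one measured step bears on this position, and because a number 3 percentage points higher from compound 1 to compound 3 (within the scatter) stayed within the scatter, the step from compound 3 to compound 4 is expected to be a number 1 percentage points lower from compound 3 to compound 4 (within the scatter), with no change beyond the scatter. Compound 4 is estimated at 5%, with a range from -5% to 15%.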

Compound 4, a percentage reported as inhibition, at one concentration (the size of the read-out at that concentration, not a potency): 1%
Estimate against measurement, compound 4: 4 percentage points above; low and high end bracket the measured number.
By their numbers in this assay, from the lowest: compounds 2, 4, 1 and 3 (each within the scatter of the next).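

With (2-((dimethylamino)methyl)-2-methylpropyl)amino on the carbonyl carbon, this assay gives a number 5 percentage points lower from compound 3 to compound 4 (within the scatter) and a number 2 percentage points lower from compound 1 to compound 4 (within the scatter). This group has no ring and brings a hydrogen-bond donor that 2-(methoxymethyl)pyrrolidin-1-yl lacks, yet neither difference moves the number beyond the scatter. Nothing available explains this result. From the compounds shown here alone, whether a carboxylic acid or a longer chain on this carbonyl carbon would give a number beyond the scatter remains open. So does whether any change elsewhere on the shared core would.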